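From chloro to amino in a cytotoxicity read-out

This account rests on a few compounds, and the source may have more. Where it says the series, first, only, none or still open, it means among the compounds named here.

Compound 1 (`COC(=O)c1ccc(NCc2cncn2Cc2ccc(Cl)cc2)cc1-c1ccccc1`): 25000 nM as a measured number
Compound 2 (`CN(C)c1ccc(NCc2cncn2Cc2ccc(-c3ccccc3)cc2)cc1-c1ccccc1`): > 1000 nM as a limit
Compound 3 (`Nc1cc(-c2ccccc2)ccc1Cn1cncc1CNc1ccc(Cl)c(-c2ccccc2)c1`): > 1000 nM as a limit

Among the compounds with values here, in a toxicity assay on NIH3T3 cells (Mus musculus) for cytotoxicity, read by resazurin assay (a lower number here means that less compound is needed, a higher number that more compound is needed for the effect), compound 1 gives 25000 nM as the only true number of the three. The other two entries are limits, and the limit of > 1000 nM in this assay, at which 2 of the 3 values shown sit, is all they offer. Compound 4 (`COC(=O)c1ccc(NCc2cncn2Cc2ccc(N)cc2)cc1-c1ccccc1`) carries amino in place of chloro on an aromatic carbon so that 4-chlorobenzyl becomes 4-aminobenzyl. Within the data shown here, no measured pair tests this change, so no step beyond the scatter is expected in this assay in either direction. The expectation rests on compound 1 at 25000 nM alone. The estimated step of a 1.2-fold higher number from compound 1 to compound 4 (0.08 log units; within the scatter) is therefore small. For compound 4 the estimate is 30000 nM (expected range 8000 nM to 100000 nM).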

Compound 4, half-maximal effective concentration: > 10000 nM
Compound 4 ended at the assay's limit; the forecaster's own chance of this, stated with the estimate: 45%; the middle value lies beyond the limit too.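

Within the data shown here, compound 4 gives > 10000 nM, which is a limit of the assay, so no step from compound 1 to compound 4 can be read. From the compounds shown here alone, whether amino in place of chloro changes this read-out at all stays open.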